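The compounds below may be only part of what the source reports. "The series", "measured", "known", "first", "only" and "open" are said of these compounds alone.

For the measured compounds named here, in an ADME assay on BHK-21 cells (Mesocricetus auratus) for cytotoxicity, read by MTT assay (a lower number here means that less compound is tolerated, a higher number that more compound is tolerated), compound 2 `COc1ccc(-c2nc3cc(/C(C)=N/NC(N)=O)ccc3n2C2CCCCC2)c(OC)c1` gives 19000 nM, the only actual number in this small set. Compound 1 `C/C(=N\NC(N)=O)c1ccc2c(c1)nc(-c1ccc(C(F)(F)F)cc1)n2C1CCCCC1` reaches only a limit of the assay, > 100000 nM. The entry for compound 3 `C/C(=N\NC(N)=O)c1ccc2c(c1)nc(-c1ccoc1)n2C1CCCCC1` is "not determined" (no result reported). Compound 4 `COc1ccc(-c2nc3cc(/C(C)=N/NC(N)=S)ccc3n2C2CCCCC2)c(OC)c1` differs from compound 2 on an amine nitrogen, where the carbamoyl is exchanged: a group of 3 heavy atoms (1 carbon, 1 nitrogen, 1 sulfur; no ring) in place of a group of 3 heavy atoms (1 carbon, 1 nitrogen, 1 oxygen; no ring), on an amine nitrogen. Going by the values given here, the one measured step, an at least 5.2-fold lower number from compound 1 to compound 2 (0.72 log units; beyond the scatter), places 2,4-dimethoxyphenyl in place of 4-(trifluoromethyl)phenyl on an aromatic carbon. It rests on a limit of > 100000 nM in this assay, at which 1 of the 3 values shown sits, and leaves the carbamoyl untouched, so it offers only a rough sense of scale. A modest move to a lower number is expected in this assay, with the estimated change being a 1.9-fold lower number from compound 2 to compound 4 (0.28 log units; within the scatter). Compound 4 is estimated at 10000 nM, with an expected range of 2500 nM to 40000 nM.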

Compound 4, half-maximal cytotoxic concentration: 17000 nM
Compound 4: middle estimate off by 1.7-fold (0.23 log units), on the low side, and the stated range covers the measured number.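

In this assay, the exchange of the carbamoyl for the group carrying sulfur in place of oxygen, on an amine nitrogen, gives a 1.1-fold lower number from compound 2 to compound 4 (0.05 log units; within the scatter), so this position shows no readable difference for this change. Unlike the earlier step, this one joins two actual numbers and keeps the 2,4-dimethoxyphenyl in place. Nothing shown gives a cause for this result. On these data alone, whether an acetyl or a methyl on that amine nitrogen would read the same remains open. So does whether the sulfur exchange would read the same with a 4-(trifluoromethyl)phenyl in place of the 2,4-dimethoxyphenyl.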